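From methoxy to methylsulfanyl in compound 4

The compounds below may be only part of what the source reports. "The series", "measured", "known", "first", "only" and "open" are said of these compounds alone.

In a functional assay on HCT-116 cells (Homo sapiens) for cytotoxicity, with a stated time of 48 h (a lower number here means a stronger inhibitor, a higher number a weaker inhibitor), compound 1 (`COc1cc(OC)c(C(=O)/C=C/c2ccccc2OC)c(OC)c1`) gives 4200 nM, compound 2 (`COc1cc(OC)c(C(=O)/C=C/c2ccccc2SC)c(OC)c1`) gives 6800 nM and compound 3 (`COc1cc(O)c(C(=O)/C=C/c2ccccc2OC)c(OC)c1`) gives 9200 nM. Compound 3 and compound 2 lie within the scatter of each other. Going by the values given here, the one step beyond the scatter is modest: a 2.2-fold higher number from compound 1 to compound 3 (0.34 log units; beyond the scatter).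

Compound 4 (`COc1cc(O)c(C(=O)/C=C/c2ccccc2SC)c(OC)c1`) differs from compound 3 in a single place, where methylsulfanyl stands in place of methoxy on an aromatic carbon, ortho to a large group: methylsulfanyl in place of methoxy on an aromatic carbon.

The same swap has been measured once, on the fully methylated compound, and it gave a 1.6-fold higher number from compound 1 to compound 2 (0.21 log units; within the scatter), which stays within the scatter. The other measured step is a different change and bears on this swap only by setting the starting point. One small step is thin evidence, so this assay is expected to show nothing beyond the scatter, at most a slight rise, with an expected change of a 1.4-fold higher number from compound 3 to compound 4 (0.15 log units; within the scatter). Compound 4 is estimated at 13000 nM, with an expected range of 7000 nM to 25000 nM.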

Compound 4, half-maximal inhibitory concentration: 10000 nM
Compound 4: the middle estimate sits 1.3-fold (0.11 log units) above what was measured; the measured number falls inside the stated range.
By their numbers in this assay, from the lowest: compounds 1, 2, 3 and 4 (each within the scatter of the next, the first and the last beyond it).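

In this assay, methylsulfanyl in place of methoxy has now been read on a second core, one with a hydrogen in place of a methyl on an oxygen, and it gives a 1.1-fold higher number from compound 3 to compound 4 (0.04 log units; within the scatter). So the small effect of this swap is not confined to the fully methylated core, and the two readings agree: the same change on two cores in this assay, a 1.6-fold higher number (0.21 log units; within the scatter) from compound 1 to compound 2 and a 1.1-fold higher number (0.04 log units; within the scatter) from compound 3 to compound 4, 1.5-fold (0.17 log units) apart, within the scatter of two such steps. The reverse comparison points the same way, since hydrogen in place of methyl on that oxygen gives a 1.5-fold higher number from compound 2 to compound 4 (0.17 log units; within the scatter) with methylsulfanyl present, and this step also agrees with its earlier counterpart: the same change on two cores in this assay, a 2.2-fold higher number (0.34 log units; beyond the scatter) from compound 1 to compound 3 and a 1.5-fold higher number (0.17 log units; within the scatter) from compound 2 to compound 4, 1.5-fold (0.17 log units) apart, within the scatter of two such steps.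

The compounds shown compare only two groups at this position, methoxy and methylsulfanyl, and each has one oxygen or sulfur joined to a methyl. On these data alone, whether an amine or a carboxylic acid there would move the number beyond the scatter remains open.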